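From Compound 2 to Compound 3: One Chain Swapped

A few compounds are considered here, and "the series" means these few. Any claim that something is new, unique, unknown or untested is made for them only; others in the source may bear on it.

Going by the values given here, in a functional assay on NCI-H1299 cells (Homo sapiens) for cytotoxicity, read by resazurin assay, with a stated time of 72 h (on this read-out lower numbers stand for stronger inhibition and higher numbers for weaker inhibition), compound 2 (`COc1cc(/C=C/C(=O)OCCCO[N+](=O)[O-])ccc1O`) gives 28300 nM, the only actual number so far. Compound 1 (`COc1cc(/C=C/C(=O)OCCCO[N+](=O)[O-])ccc1OCCCO[N+](=O)[O-]`) gives > 50000 nM, which is a limit of the assay and not a number.

Compound 3 (`COc1cc(/C=C/C(=O)OC/C=C/CO[N+](=O)[O-])ccc1O`) differs from compound 2 in one place: a group of 7 heavy atoms (3 carbon, 1 nitrogen, 3 oxygen; no ring) in place of a group of 6 heavy atoms (2 carbon, 1 nitrogen, 3 oxygen; no ring), on a saturated chain carbon bound to an oxygen next to a carbonyl group. The swap sits on a saturated chain carbon bound to an oxygen next to a carbonyl group, and neither group contains a ring.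

Among the compounds with values here, the only measured step available is an at least 1.7-fold lower number from compound 1 to compound 2 (0.24 log units; that floor lies within the scatter). Its size is a floor that lies within the scatter, and it concerns a different place, on an oxygen on an aromatic ring. That floor comes from compound 1, which sits at the limit of > 50000 nM in this assay, at which 1 of the 2 values shown sits. Within the data shown here, no measured step therefore tests this chain swap, so no shift beyond the scatter is expected in this assay, in either direction. The expected change is a 1.1-fold lower number from compound 2 to compound 3 (0.05 log units; within the scatter), which would lie within the scatter. Compound 3 is estimated at about 25000 nM, with an expected range from 10000 nM to 50000 nM.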

Compound 3, half-maximal inhibitory concentration: 2340 nM
Estimate against measurement, compound 3: 11-fold (1.03 log units) above; measured number below the stated range.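

Going by these compounds alone, this swap is the first change to move the number beyond the scatter: in this assay it gives a 12-fold lower number from compound 2 to compound 3 (1.08 log units; beyond the scatter). So the place on a saturated chain carbon bound to an oxygen next to a carbonyl group is sensitive to change, and here both ends of the step are actual numbers, which the earlier step on an oxygen on an aromatic ring could not offer. The two groups match in hydrogen-bond donors, hydrogen-bond acceptors and net charge and differ in heavy atoms and in double bonds outside aromatic rings, but nothing given here explains why the number falls.

The entering group differs from the leaving one in both heavy atoms and double bonds, so the compounds shown cannot separate these two differences, and a longer saturated chain carrying the same nitrooxy end would be needed to tell them apart. They also leave open whether the nitrooxy end matters to this step at all, a question that a chain ending in a hydroxyl group would address.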